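The source may report more compounds than this note shows. Statements on the series, on what has been measured and on what is new or still open speak of the compounds shown alone.

Measured so far:
compound 1 `O=C(COc1ccc2c(=O)ccoc2c1)Nc1cccc(NC(=O)c2ccc(OC(F)(F)F)cc2)c1` — 77 nM
compound 2 `Cc1cc(C(=O)Nc2cccc(NC(=O)COc3ccc4c(=O)ccoc4c3)c2)ccc1C(F)(F)F` — 43 nM

Both compounds were run in an assay on isolated protein for inhibition of Rho-associated protein kinase 2 (Homo sapiens), read by scintillation counting, radiometric assay and 33P incorporation, with a stated time of 40 min, in the presence of a further agent that is not named here; on this read-out higher numbers stand for weaker inhibition and lower numbers for stronger inhibition. For the measured compounds named here, compound 2 carries the smaller of the two numbers, yet the only measured step, a 1.8-fold lower number from compound 1 to compound 2 (0.25 log units; within the scatter), lies within the scatter, so compound 2 and compound 1 cannot be told apart on this read-out.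

Compound 3 `Cc1nc(C(=O)Nc2cccc(NC(=O)COc3ccc4c(=O)ccoc4c3)c2)cs1` is not yet measured. Its change from compound 2 is a group of 6 heavy atoms (4 carbon, 1 nitrogen, 1 sulfur; one five-membered aromatic ring with 2 hetero atoms) in place of a group of 11 heavy atoms (8 carbon, 3 fluorine; one six-membered aromatic ring of carbon only), on a carbonyl carbon. Going by the values given here, no measured step bears directly on this exchange: the single step available, a 1.8-fold lower number from compound 1 to compound 2 (0.25 log units; within the scatter), concerns a different group on the carbonyl carbon and is within the scatter. Among the compounds with values here, there is thus no ground in the numbers for a directed expectation, and the series so far is flat. In this assay compound 3 is therefore estimated at 90 nM, with a range from 30 nM to 300 nM. The step expected here is a 2.1-fold higher number from compound 2 to compound 3 (0.32 log units; beyond the scatter), not clearly beyond the scatter.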

Compound 3, half-maximal inhibitory concentration: 33 nM
Beside the measured number, compound 3's estimate is 2.7-fold (0.44 log units) above it, within the range that was stated.
By their numbers in this assay, from the lowest: compounds 3, 2 and 1 (each within the scatter of the next, the first and the last beyond it).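

In this assay, the 2-methyl-1,3-thiazol-4-yl group on this carbonyl carbon cannot be told apart from the larger group of compound 2 (a 1.3-fold lower number from compound 2 to compound 3 (0.11 log units; within the scatter)), so a five-membered aromatic ring with 2 hetero atoms and no fluorine keeps the number in the same range. Set against the 4-(trifluoromethoxy)phenyl group, the same group gives the only step in the series beyond the scatter, and a modest one (a 2.3-fold lower number from compound 1 to compound 3 (0.37 log units; beyond the scatter)), while compound 2 lies within the scatter of both compound 1 and compound 3. Nothing at hand accounts for either step.

Going by these compounds, what the number becomes with a 1,3-thiazol-4-yl group lacking the methyl, or with a saturated ring carrying an amine or a carboxylic acid on this carbonyl carbon, stays open. Also open, on these data alone, is how the number responds to changes elsewhere on the shared core, since these three compounds differ only at this carbonyl carbon.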